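Triazole-Ketone Series: Ester for Chloride on the Aryl Ring

The source may hold more compounds than are shown below. What is called first, only, known or untested is meant among the compounds shown, and "the series" means these compounds.

Measured so far:
Compound 1, `CCCCCCCCc1ccc(OCC(=O)Cn2nnc(-c3cccc(Cl)c3)n2)cc1`, gives 24 nM in an assay on microsomes from brain for inhibition of Fatty-acid amide hydrolase 1 (Rattus norvegicus), read by fluorescence and HPLC, with a stated time of 60 min; a lower number here means a stronger inhibitor, a higher number a weaker inhibitor.
Compound 2, `CCCCCCCCc1ccc(OCC(=O)Cn2nnc(-c3cccc(C(=O)OC)c3)n2)cc1`, gives 34 nM in this assay.
Compound 3, `CCCCCCCCc1ccc(OC(C)C(=O)Cn2nnc(-c3ccc(Cl)cc3)n2)cc1`, gives 35 nM in this assay.

Compound 4, `CCCCCCCCc1ccc(OC(C)C(=O)Cn2nnc(-c3ccc(C(=O)OC)cc3)n2)cc1`, has not been measured. It is related to compound 3 in the way compound 2 is related to compound 1; the difference between the core of compound 1 and the core of compound 3 is not broken down here.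

The change from compound 1 to compound 2 is methoxycarbonyl in place of chloro on an aromatic carbon and it produced a 1.4-fold higher number from compound 1 to compound 2 (0.15 log units; within the scatter). The change from compound 3 to compound 4 is methoxycarbonyl in place of chloro on an aromatic carbon. This is the same kind of change, not the same one: in the first pair the group sits meta to a large group, in the second pair para to a large group.

Among the measured compounds shown here, since the only measured example of this kind of change, a 1.4-fold higher number from compound 1 to compound 2 (0.15 log units; within the scatter), stayed within the scatter, compound 4 is expected to show a 1.3-fold higher number from compound 3 to compound 4 (0.11 log units; within the scatter) in this assay. Compound 4 is therefore estimated at 45 nM, with a range from 20 nM to 110 nM.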

Compound 4, half-maximal inhibitory concentration: 25 nM
Compound 4: middle estimate off by 1.8-fold (0.26 log units), on the high side, and the stated range covers the measured number.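

In this assay, placing methoxycarbonyl where chloro stood on the core of compound 3 gave a 1.4-fold lower number from compound 3 to compound 4 (0.15 log units; within the scatter), and the step agrees with the earlier one on the core of compound 1: the same change on two cores in this assay, a 1.4-fold higher number (0.15 log units; within the scatter) from compound 1 to compound 2 and a 1.4-fold lower number (0.15 log units; within the scatter) from compound 3 to compound 4, 2.0-fold (0.30 log units) apart, within the scatter of two such steps On these two cores, then, the exchange left the number within the scatter, and the opposite directions of the two steps cannot be read as a real reversal. Among the compounds shown here, this does not show that the change carries over generally, since there are only two pairs, and they differ both in the core and in where the group sits, with the second pair having it para to a large group, so the two influences cannot be told apart.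

On these data alone, it remains open whether a carboxylic acid or an amide in place of the methoxycarbonyl would also stay within the scatter of the chloro compounds in this assay. The same question stands for a nitrile or a trifluoromethyl group at this place on the aryl ring.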